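A few compounds are considered here, and "the series" means these few. Any claim that something is new, unique, unknown or untested is made for them only; others in the source may bear on it.

In an ADME assay on PBMC cells (Homo sapiens) for cytotoxicity, with a stated time of 5 days (on this read-out lower numbers stand for stronger inhibition and higher numbers for weaker inhibition), compound 2 `CC(C)(CO)Nc1nc(N)nc2c1ncn2[C@H]1C[C@H](N=[N+]=[N-])[C@@H](CO)O1` gives > 100000 nM, which is a limit of the assay and not a number. Compound 1 `COc1nc(NC2CC2)c2ncn([C@H]3C[C@H](N=[N+]=[N-])[C@@H](CO)O3)c2n1` gives > 100000 nM, which is also a limit. Compound 3 `COc1nc(N)c2ncn([C@H]3C[C@H](N=[N+]=[N-])[C@@H](CO)O3)c2n1` gives 35000 nM, a true number. The measurements therefore leave little room for comparison, with the limit of > 100000 nM in this assay, at which 2 of the 3 values shown sit, setting the ceiling.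

The next compound is compound 4 `[N-]=[N+]=N[C@H]1C[C@H](n2cnc3c(NCCO)nc(N)nc32)O[C@@H]1CO`, and the change is 2-hydroxyethyl in place of 1-(hydroxymethyl)-1-methylethyl on a nitrogen on an aromatic ring.

Among the compounds with values here, only one measured step bears on this. It is an at least 2.8-fold lower number from compound 1 to compound 3 (0.45 log units; beyond the scatter), which also swaps the group on a nitrogen on an aromatic ring, though in a different pair of compounds and with different groups. That step suggests a modest move toward a lower number in this assay, but the reading could well stay at the limit.

The expected change is an at least 1.4-fold lower number from compound 2 to compound 4 (0.15 log units; that floor lies within the scatter). For compound 4 the estimated value is 70000 nM, with an expected range from 25000 nM to 100000 nM.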

Compound 4, half-maximal inhibitory concentration: > 100000 nM
Compound 4: no number, only a limit; the forecaster's own chance of this, stated with the estimate: 55%; middle value at least 1.4-fold (0.15 log units) away from the limit.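

Compound 4 gives > 100000 nM, which is a limit and not a number, and compound 2 also stands at a limit, so no step between them can be read: the limit of > 100000 nM in this assay, at which 3 of the 4 values shown sit.

On these data alone, whether 2-hydroxyethyl and 1-(hydroxymethyl)-1-methylethyl on that nitrogen give different readings in this assay stays open.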